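Removing one methoxy group from a cinnamaldehyde-bearing lignan scaffold

This account rests on a few compounds, and the source may have more. Where it says the series, first, only, none or still open, it means among the compounds named here.

Measured so far:
compound 1 `COc1cc([C@H]2Oc3c(OC)cc(/C=C/C=O)cc3[C@@H]2CO)cc(OC)c1O` — 19300 nM
compound 2 `C[C@H](c1ccccc1)c1cccc([C@@H](C)c2ccccc2)c1O` — > 100000 nM

The account concerns two measured compounds and one whose value is still to come. Among the measured compounds shown here, in a functional assay on cells (Neutrophil, Homo sapiens), with a stated time of 5 min (a lower number here means a stronger inhibitor, a higher number a weaker inhibitor), compound 1 gives 19300 nM, the only actual number in the set. Compound 2 is a different scaffold altogether, and in this assay compound 2 returns only a limit of > 100000 nM, which marks the edge of what the assay can report rather than a measured potency (the limit of > 100000 nM in this assay, at which 1 of the 2 values shown sits). For the measured compounds named here, compound 1 therefore stands alone as the single fixed point, with no measured step between two compounds available to calibrate the effect of any change.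

The unmeasured compound 3 `COc1cc([C@H]2Oc3c(OC)cc(/C=C/C=O)cc3[C@@H]2CO)ccc1O` shares the core of compound 1 and differs in one place: hydrogen in place of methoxy on an aromatic carbon. Going by the values given here, no step of comparable kind is among the measured pairs, so the expected size rests on the change itself. For compound 3 the step from compound 1 is expected to stay small, likely within or near the scatter, with no clear direction a 1.0-fold higher number from compound 1 to compound 3 (0.02 log units; within the scatter). Compound 3 is thus estimated at 20000 nM in this assay, within a range of 7000 nM to 60000 nM.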

Compound 3, half-maximal inhibitory concentration: 31900 nM
Compound 3: middle estimate off by 1.6-fold (0.20 log units), on the low side; the measured number falls inside the stated range.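

In this assay, the only measured step among the compounds shown is a 1.7-fold higher number from compound 1 to compound 3 (0.22 log units; within the scatter) for hydrogen in place of methoxy on an aromatic carbon, ortho to a hydroxy group and meta to a methoxy group. This gives the shared core its first calibration: at this position, the loss of the methoxy group, with its 2 heavy atoms, produces no difference that this assay can separate from the usual scatter of repeated measurements, so compound 1 and compound 3 stand as a matched pair, not as a stronger and a weaker member. Nothing among the data shown bears on why this replacement leaves the read-out within the scatter, and no cause can be assigned to it.

The compounds shown leave open whether this position would accept something other than hydrogen or methoxy, such as a fluorine atom, an amine or a longer chain like ethoxy. They also leave open what happens at other places on the shared core, including the remaining methoxy group, the hydroxy group and the aldehyde.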